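The source may report more compounds than this note shows. Statements on the series, on what has been measured and on what is new or still open speak of the compounds shown alone.

Measured compounds:
- compound 1, `CCN(C)C(=O)N1CCN(C(=S)SCc2cn(Cc3ccccc3F)nn2)CC1`: 5860 nM
- compound 2, `NC(=O)N1CCN(C(=S)SCc2cn(Cc3ccc(F)cc3)nn2)CC1`: 9330 nM
- compound 3, `CC(C)NC(=O)N1CCN(C(=S)SCc2cn(Cc3ccc(F)cc3)nn2)CC1`: 760 nM

In a functional assay on MGC-803 cells (Homo sapiens) for cytotoxicity, read by MTT assay, with a stated time of 72 h (a higher number here means a weaker inhibitor, a lower number a stronger inhibitor), compound 3 gives the lowest number of the three, with compound 1 the nearest and compound 2 the furthest, both beyond the scatter. Among the compounds with values here, the one step that can be compared directly, a 12-fold lower number from compound 2 to compound 3 (1.09 log units; beyond the scatter), shows that filling the amide-type nitrogen with an isopropyl group brings a large gain.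

Compound 4, `CCN(C)C(=O)N1CCN(C(=S)SCc2cn(Cc3ccc(F)cc3)nn2)CC1`, is the next compound. Compared with compound 3 the change is ethyl(methyl)amino in place of isopropylamino on a carbonyl carbon; the same atoms are kept but joined differently, so the hydrogen-bond donor on that nitrogen is lost while the carbon count stays the same.

Within the data shown here, no measured step follows this exact change. Compound 1 carries the same ethyl(methyl)amino group on its carbonyl carbon, yet differs from compound 4 in another part of the molecule; in this assay compound 1 gives 5860 nM, which can only hint that this group is compatible with moderate activity. Because the gain a 12-fold lower number from compound 2 to compound 3 (1.09 log units; beyond the scatter) came with a substituent that also kept the hydrogen, the expectation is that compound 4 sits somewhat above compound 3, a step of a 3.3-fold higher number from compound 3 to compound 4 (0.52 log units; beyond the scatter) weaker. Compound 4 is therefore estimated at 2500 nM, within 800 nM to 8000 nM.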

Compound 4, half-maximal inhibitory concentration: 1550 nM
Estimate against measurement, compound 4: 1.6-fold (0.21 log units) above; the range from low to high includes it.
By their numbers in this assay, from the lowest: compound 3; then compound 4; then compounds 1 and 2 (each within the scatter of the next).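

In this assay, rearranging the same atoms from isopropylamino to ethyl(methyl)amino on the carbonyl carbon gives a 2.0-fold higher number from compound 3 to compound 4 (0.31 log units; beyond the scatter) and so shows that this position responds to how the atoms are joined, not just to how many there are; the swap also removes the one hydrogen-bond donor counted on the isopropylamino group. Even so, the donor-free group keeps much of the advantage over the plain amino group, with a 6.0-fold lower number from compound 2 to compound 4 (0.78 log units; beyond the scatter) as the step, so among these compounds a gain over amino does not depend on keeping a donor at this place. The fluorine's place on the phenyl ring also matters, since 4-fluorophenyl in place of 2-fluorophenyl on the saturated chain carbon bound to an aromatic nitrogen gives a 3.8-fold lower number from compound 1 to compound 4 (0.58 log units; beyond the scatter) as a separate, directly readable step.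

No measurement shown here explains why any of these steps has the size it does. Also open, going by these compounds, is how a dimethylamino, tert-butylamino or morpholine group on the same carbonyl carbon would compare with isopropylamino, and whether a chlorine on the phenyl ring would follow the pattern seen with fluorine.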